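This account rests on a few compounds, and the source may have more. Where it says the series, first, only, none or still open, it means among the compounds named here.

Of the compounds shown here, two have been measured so far in an assay (Equus caballus) for inhibition of Thromboxane-A synthase (Homo sapiens), using microsomes; on this read-out lower numbers stand for stronger inhibition and higher numbers for weaker inhibition. Compound 1 `O=C(O)C(CCC/C=C(\c1ccccc1)c1cccnc1)Sc1ccccc1` gives 33 nM in this assay, the highest of the two numbers, while compound 2 `O=C(O)CCCC/C=C(\c1cccnc1)c1cccs1` gives 20 nM; the two numbers lie within the scatter of each other, so neither can be called the stronger inhibitor. Compound 3 `O=C(O)C(CCC/C=C(\c1ccccc1)c1cccnc1)C1=CCCC1` has not yet been measured. It differs from compound 1 in one place: cyclopent-1-en-1-yl in place of phenylsulfanyl on a saturated chain carbon bound to a carbonyl carbon and a saturated chain carbon. Going by the values given here, no pair of measured compounds shares this change, so there is no direct guide to its size. Compound 1 and compound 2 differ in more than one place and still land within the scatter, which offers only weak reassurance. Compound 3 is therefore expected to show a step of a 1.2-fold higher number from compound 1 to compound 3 (0.08 log units; within the scatter), not beyond the scatter in either direction. Compound 3 is estimated at 40 nM, with a range from 10 nM to 160 nM.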

Compound 3, half-maximal inhibitory concentration: 60 nM
For compound 3 the middle estimate is 1.5-fold (0.18 log units) below the measured one, within the range that was stated.
By their numbers in this assay, from the lowest: compounds 2, 1 and 3 (each within the scatter of the next, the first and the last beyond it).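

In this assay, cyclopent-1-en-1-yl in place of phenylsulfanyl on a saturated chain carbon bound to a carbonyl carbon and a saturated chain carbon gives a step of a 1.8-fold higher number from compound 1 to compound 3 (0.26 log units; within the scatter), the first single-place change read at this position. In this one pair, the sulfur and the six-membered aromatic ring leave together, a five-membered non-aromatic ring of carbon only enters, and the step stays within the scatter. Nothing available explains this step or separates the contributions of the sulfur and the ring.

On these data alone, it remains open whether a phenyl group bound directly to this carbon, an amine or a longer alkyl chain would also stay within the scatter of compound 1. As far as these compounds go, it is also open whether this position needs a ring at all.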